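Adding a Chlorine to a Compound at the Assay Limit

The compounds below may be only part of what the source reports. "The series", "measured", "known", "first", "only" and "open" are said of these compounds alone.

Two measured compounds share the same core and differ only in the group attached at one end. Compound 1 `COc1cc(-c2noc(Cc3c[nH]c4ccccc34)n2)cc(OC)c1OC` and compound 2 `c1ccc(-c2noc(Cc3c[nH]c4ccccc34)n2)cc1` were both tested in a functional assay on cells (Splenocyte, Mus musculus, strain BALB/c) for inhibition, read by scintillation counting and thymidine incorporation, with stated times of 48 h and 8 h; on this read-out higher numbers stand for weaker inhibition and lower numbers for stronger inhibition. In this assay compound 1 gives > 50000 nM, which is a limit of the assay rather than a number. Compound 2 likewise gives > 50000 nM, again a limit and not a number. So compound 2 stands at the limit of > 50000 nM in this assay, at which 2 of the 2 values shown sit, and no measured step between the two compounds can be drawn.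

Compound 3 `Clc1ccc(-c2noc(Cc3c[nH]c4ccccc34)n2)cc1` has not yet been measured. It differs from compound 2 by chloro in place of hydrogen on an aromatic carbon. Cut one bond further out, the same change reads phenyl to 4-chlorophenyl.

With both measured values sitting at the limit, nothing in the data points to inhibition becoming measurable. The step expected from this change is a step that the limit leaves unreadable from compound 2 to compound 3, none beyond the usual scatter. Compound 3 is therefore expected to give about 60000 nM in this assay, within a range of 20000 nM to 200000 nM, most likely reported again only as a limit.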

Compound 3, half-maximal inhibitory concentration: 22600 nM
Compound 3: the middle estimate sits 2.7-fold (0.42 log units) above what was measured; the measured number falls inside the stated range.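

In this assay, chloro in place of hydrogen on an aromatic carbon, para to a large group, gives an at least 2.2-fold lower number from compound 2 to compound 3 (0.34 log units; beyond the scatter). For the compounds shown here, this shows that the position can change the read-out, and that a single chlorine atom is enough to bring a measurable number, as compound 3 gives 22600 nM, the only value shown that is not a limit. The true size of the step remains unknown because the starting point is a limit rather than a number, so the step gives only a minimum: the limit of > 50000 nM in this assay, at which 2 of the 3 values shown sit.

Going by these compounds, whether this change belongs to chlorine in particular or would appear with other groups at the same place remains open, and fluoro, bromo, methyl, an amine or a carboxylic acid there would help to separate these possibilities. The compounds shown also leave open whether a further change at this position could bring the number much lower, since a single measured value gives no trend to follow.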